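Adding Chloro to Compound 1: An Expected Cytotoxicity Step

The source may report more compounds than this note shows. Statements on the series, on what has been measured and on what is new or still open speak of the compounds shown alone.

Measured compounds:
compound 1, `CCn1cc(-c2nc3ccccc3[nH]2)c(=O)c2cc(F)c(N3CCNCC3)cc21`, > 10000 nM
compound 2, `CCn1cc(-c2nc3ccccc3[nH]2)c(=O)c2cc(F)c(N3CCNCC3)nc21`, 6600 nM

Of the compounds shown here, two have so far been tested in a functional assay on AGS cells (Homo sapiens) for cytotoxicity, read by sulforhodamine B assay, with a stated time of 48 h; a lower number here means a stronger inhibitor, a higher number a weaker inhibitor. For compound 1 the assay reports only a limit, > 10000 nM, which is the limit of > 10000 nM in this assay, at which 1 of the 2 values shown sits. Compound 2, whose structure is `CCn1cc(-c2nc3ccccc3[nH]2)c(=O)c2cc(F)c(N3CCNCC3)nc21`, gives a number, 6600 nM, in this assay. No step between these two is shown; the values show only that compound 2 yields a number where compound 1 yields a limit.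

Compound 3, `CCn1cc(-c2nc3ccc(Cl)cc3[nH]2)c(=O)c2cc(F)c(N3CCNCC3)cc21`, is the next one to be tested. It differs from compound 1 by chloro in place of hydrogen on an aromatic carbon. Within the data shown here, since no measured step of this kind is available, the expected size of the move in this assay rests on the single weak value of compound 1 alone. The estimated step of an at least 1.2-fold lower number from compound 1 to compound 3 (0.09 log units; that floor lies within the scatter) is small, no more than the usual scatter, perhaps a modest gain. Compound 3 is therefore expected to give about 8000 nM in this assay, within a range from 2500 nM to 30000 nM.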

Compound 3, half-maximal inhibitory concentration: 1000 nM
Compound 3: the middle estimate sits 8.0-fold (0.90 log units) above what was measured; measured number outside the range, below it.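

In this assay, replacing the 1H-benzimidazol-2-yl group of compound 1 with the 6-chloro-1H-benzimidazol-2-yl group gives an at least 10-fold lower number from compound 1 to compound 3 (1.00 log units; beyond the scatter). Among these compounds, this is the first measured change at this aromatic carbon, meta to a fused ring and para to a fused ring, and it shows that a single chloro in place of hydrogen here is enough to turn a reading at the limit of the assay into a number that lies beyond the scatter. The value of compound 1, > 10000 nM, is a limit and not a number, so the step gives only a floor, and its full size cannot be read because compound 1 sits at that limit: the limit of > 10000 nM in this assay, at which 1 of the 3 values shown sits.

The compounds shown leave open whether fluoro, bromo, methoxy or an amine on this same aromatic carbon would move the number as chloro does, and whether the gain belongs to chloro in particular or to any group in place of hydrogen there. They also leave open whether chloro would bring a similar step on the core of compound 2, which gives 6600 nM.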